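The compounds below may be only part of what the source reports. "The series", "measured", "known", "first", "only" and "open" are said of these compounds alone.

Compound 1 `CN(C[C@H]1Cc2c(cccc2N2CCN(c3ncccn3)CC2)CN1)[C@H]1CCCc2cccnc21` and compound 2 `c1cnc2c(c1)CCC[C@@H]2N(CC1CCCCC1)C[C@H]1Cc2c(cccc2N2CCNCC2)CN1` both reach only the limit of a functional assay on CCRF-CEM cells for agonist activity at C-X-C chemokine receptor type 4 (Homo sapiens), read by calcium flux, with a stated time of 25 min; a higher number here means that more compound is needed for the effect, a lower number that less compound is needed. In this assay compound 1 gives > 30000 nM, a limit rather than a number. Compound 2 likewise gives > 30000 nM in this assay, again a limit. Compound 2 thus stands at the limit shared by both values shown (the limit of > 30000 nM in this assay, at which 2 of the 2 values shown sit). Compound 3 `CN(C[C@H]1Cc2c(cccc2N2CCNCC2)CN1)[C@H]1CCCc2cccnc21` differs from compound 2 by hydrogen in place of cyclohexyl on a saturated chain carbon bound to an amine nitrogen. For the measured compounds named here, with both measured values sitting at the limit, no step can be sized. Compound 3 is expected to remain near that limit, with a step of a number no higher from compound 2 to compound 3 (the limit leaves the size open) not beyond the scatter. Compound 3 is therefore estimated at 30000 nM, within 10000 nM to 100000 nM.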

Compound 3, half-maximal effective concentration: > 30000 nM
Compound 3 ended at the assay's limit (the forecaster's own chance of this, stated with the estimate: 75%); the middle value sits exactly at the limit.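

In this assay, for the compounds shown here, no step to compound 3 from compound 1 or compound 2 can be read, as all three compounds stand at one limit: the limit of > 30000 nM in this assay, at which 3 of the 3 values shown sit. Whether any change among these compounds moves the result in this assay stays open.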